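Swapping the aryl ether tail on a shared sesquiterpene-type core

A few compounds are considered here, and "the series" means these few. Any claim that something is new, unique, unknown or untested is made for them only; others in the source may bear on it.

Three analogues sharing one core have been measured in a functional assay on SGC-7901 cells (Homo sapiens) for cytotoxicity, read by sulforhodamine B assay, with a stated time of 72 h; a lower number here means a stronger inhibitor, a higher number a weaker inhibitor. Compound 1 `C=C1C(=O)O[C@@H]2CC(C)=C([C@@H](C)CCCOC(C)=O)[C@@H](OC(=O)CCl)[C@H]12` gives 26500 nM, compound 2 `C=C1C(=O)O[C@@H]2CC(C)=C([C@@H](C)CCCOC(C)=O)[C@@H](OC(=O)COc3cccc(C(C)=O)c3)[C@H]12` gives 46100 nM, and compound 3 `C=C1C(=O)O[C@@H]2CC(C)=C([C@@H](C)CCCOC(C)=O)[C@@H](OC(=O)COc3ccc4c(CC)noc4c3)[C@H]12` gives 21200 nM. Compound 2 stands at the highest of the three numbers: its nearest neighbour is compound 1, at a distance within the scatter, and its furthest is compound 3, beyond the scatter, as shown by a 2.2-fold lower number from compound 2 to compound 3 (0.34 log units; beyond the scatter).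

Compound 4 `C=C1C(=O)O[C@@H]2CC(C)=C([C@@H](C)CCCOC(C)=O)[C@@H](OC(=O)COc3cccc4[nH]nnc34)[C@H]12` is not yet measured. It differs from compound 2 by a group of 9 heavy atoms (6 carbon, 3 nitrogen; one five-membered aromatic ring with 3 hetero atoms, one six-membered aromatic ring of carbon only) in place of a group of 9 heavy atoms (8 carbon, 1 oxygen; one six-membered aromatic ring of carbon only), on an oxygen on a saturated carbon. Within the data shown here, the step that bears most directly on this change is the one from compound 2 to compound 3, where another aromatic bicyclic group took the place of the 3-acetylphenyl group and the number fell by a 2.2-fold lower number from compound 2 to compound 3 (0.34 log units; beyond the scatter). The step of a 1.7-fold higher number from compound 1 to compound 2 (0.24 log units; within the scatter) shows that adding the 3-acetylphenoxy group to the chloro parent moved the number only within the scatter, and a 1.3-fold lower number from compound 1 to compound 3 (0.10 log units; within the scatter) likewise stayed within the scatter.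

On this basis compound 4 is expected to give a number in this assay somewhat lower than compound 2, about a 1.7-fold lower number from compound 2 to compound 4 (0.23 log units; within the scatter), though a result within the scatter of compound 2 would not surprise. The estimate for compound 4 is 27000 nM, with a range from 12000 nM to 60000 nM.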

Compound 4, half-maximal inhibitory concentration: 21100 nM
The estimate for compound 4 lay 1.3-fold (0.11 log units) above the measured number, and the stated range covers the measured number.
By their numbers in this assay, from the lowest: compounds 4, 3, 1 and 2 (each within the scatter of the next, the first and the last beyond it).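

In this assay, a second two-ring aromatic group in place of the 3-acetylphenyl group on this oxygen gives a 2.2-fold lower number from compound 2 to compound 4 (0.34 log units; beyond the scatter), a step beyond the scatter like the one seen earlier with the group of compound 3, so the gap from compound 2 no longer rests on a single replacement. The two two-ring groups differ in their hetero atoms and heavy-atom count, yet they cannot be told apart, with a 1.0-fold lower number from compound 3 to compound 4 (0.00 log units; within the scatter), and the group with three ring nitrogens is also not separated from the chloro parent, with a 1.3-fold lower number from compound 1 to compound 4 (0.10 log units; within the scatter), which means that compound 1 stays within the scatter of both compound 3 and compound 4 and the only separation lies between these last two and compound 2. Nothing given here accounts for why the number shifts with this change.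

Going by these compounds, it remains open whether a plain phenyl, or a phenyl ring carrying an amine or a carboxylic acid, would sit with compound 2 or with compound 4. Also open, on these data alone, is what a free hydroxyl in place of the acetate ester on the side chain would do, since all four compounds carry that ester on the shared core.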